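A few compounds are considered here, and "the series" means these few. Any claim that something is new, unique, unknown or untested is made for them only; others in the source may bear on it.

Measured compounds in an assay on CHO cells for positive allosteric modulation of metabotropic glutamate receptor 5 (Homo sapiens), read by FLIPR; on this read-out lower numbers stand for an effect already at smaller amounts and higher numbers for an effect only at larger amounts of compound:

compound 1 `O=C(Nc1cccc(F)c1CN1C(=O)c2ccccc2C1=O)c1ccccn1` – > 100000 nM
compound 2 `O=C(Nc1ccc(Cl)cc1CN1C(=O)c2ccccc2C1=O)c1ccco1` – 2300 nM
compound 3 `O=C(Nc1ccc(Cl)cc1CN1C(=O)c2ccccc2C1=O)C1CCCCC1` – 1500 nM

The value of compound 1 in this assay is a limit of the assay and not a number (the limit of > 100000 nM in this assay, at which 1 of the 3 values shown sits). Compound 2 and compound 3 each give a number in this assay, and the step of a 1.5-fold lower number from compound 2 to compound 3 (0.19 log units; within the scatter) concerns only the group on the carbonyl carbon, not the substitution of the shared core.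

Compound 4 `O=C(Nc1ccccc1CN1C(=O)c2ccccc2C1=O)c1ccccn1` has not been measured in this assay. It differs from compound 1 by hydrogen in place of fluoro on an aromatic carbon. Among the compounds with values here, no measured pair shows this change: the single measured step of a 1.5-fold lower number from compound 2 to compound 3 (0.19 log units; within the scatter) alters a different part of the molecule, and compounds 2 and 3 carry chloro rather than fluoro on the shared core, with other groups on the carbonyl carbon, so they give no direct anchor for the removal of fluoro from compound 1. The expectation for compound 4 therefore rests on compound 1 standing at the limit, with the possibility that compound 4 comes into the measurable range, and is wide. For compound 4 the expected value in this assay is 30000 nM, with a range from 3000 nM to 100000 nM. For compound 4 the expected step is an at least 3.3-fold lower number from compound 1 to compound 4 (0.52 log units; beyond the scatter).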

Compound 4, half-maximal effective concentration: 13900 nM
For compound 4 the middle estimate is 2.2-fold (0.33 log units) above the measured one; the measured number falls inside the stated range.
By their numbers in this assay, from the lowest: compounds 3 and 2 (each within the scatter of the next); then compound 4. At a limit, above all of these: compound 1.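

Hydrogen in place of fluoro, on an aromatic carbon ortho to a large group and meta to a ((pyridin-2-yl)carbonyl)amino group, gives in this assay the only step shown that touches the substitution of the shared core: an at least 7.1-fold lower number from compound 1 to compound 4 (0.85 log units; beyond the scatter). This step gives only a minimum size, as compound 1 stands at a limit of the assay and not a number: the limit of > 100000 nM in this assay, at which 1 of the 4 values shown sits. Compound 4 gives 13900 nM. A pyridin-2-yl group on the carbonyl carbon therefore does not by itself hold a compound at the limit, and in this pair the fluoro on this carbon marks the difference between a limit and a number.

Open, going by these compounds, is whether a methyl or a methoxy group on this same aromatic carbon would behave like fluoro or like hydrogen, and whether the result belongs to this carbon or would also follow from fluoro elsewhere on the ring. Within the data shown here, also open is whether hydrogen in place of chloro would move the numbers of compound 2 and compound 3, as these carry other groups on the carbonyl carbon and no pair links them to compound 4.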